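Swapping the Anilino Ring on a Shared Kinase Inhibitor Core

This account rests on a few compounds, and the source may have more. Where it says the series, first, only, none or still open, it means among the compounds named here.

Compound 1 `COc1ccc(Nc2ncc(C(F)(F)F)c(N3Cc4cccc(N(C)S(C)(=O)=O)c4C3)n2)cc1C(F)(F)F` gives > 20000 nM in an assay on Sf9 cells for inhibition of tyrosine-protein kinase receptor UFO (Homo sapiens), read by luminescence and ADP-Glo (a higher number here means a weaker inhibitor, a lower number a stronger inhibitor), which is a limit of the assay, not a number.
Compound 2 `Cc1ccc(Nc2ncc(C(F)(F)F)c(N3Cc4cccc(N(C)S(C)(=O)=O)c4C3)n2)cc1C` gives > 20000 nM in this assay, again a limit of the assay.

Compound 1 therefore stands only at the limit of > 20000 nM in this assay, at which 2 of the 2 values shown sit. Compound 2 differs from it by a 3,4-dimethylphenyl in place of 4-methoxy-3-(trifluoromethyl)phenyl on a nitrogen on an aromatic ring, and the step from compound 1 to compound 2 is a step that the two limits leave unreadable from compound 1 to compound 2. Compound 3 `Cc1ccc(Nc2ncc(C(F)(F)F)c(N3Cc4cccc(N(C)S(C)(=O)=O)c4C3)n2)c(Cl)c1` carries 2-chloro-4-methylphenyl in place of 4-methoxy-3-(trifluoromethyl)phenyl on a nitrogen on an aromatic ring. Among the compounds with values here, no measured step bears readably on this change, so no direction can be read from compound 1 and compound 2. Compound 3 is expected near 20000 nM, within 5000 nM to 60000 nM. The expected step is a number no higher from compound 1 to compound 3 (the limit leaves the size open), most likely again reported as a limit.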

Compound 3, half-maximal inhibitory concentration: > 20000 nM
Compound 3: only a limit was reported; the forecaster's own chance of this, stated with the estimate: 85%; the middle value lies on the limit itself.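

Within the data shown here, compound 1, compound 2 and compound 3 all sit at the same limit of the assay, so no step among them can be read: the limit of > 20000 nM in this assay, at which 3 of the 3 values shown sit.
The compounds shown leave open how these three rings on the shared core truly rank in this assay, since none gives an actual number.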